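Swapping Cyclopropyl for Thiophen-2-yl: Permeability Outlook

A few compounds are considered here, and "the series" means these few. Any claim that something is new, unique, unknown or untested is made for them only; others in the source may bear on it.

Of the compounds shown here, three sharing one core have been measured in an ADME assay on Caco-2 cells (Homo sapiens) for permeability, in the apical to basolateral direction; on this read-out lower numbers stand for lower permeability and higher numbers for higher permeability. Compound 1 `Cn1cncc1CN1CC(N(CC2CCN(C(=O)C(C)(C)C)CC2)S(=O)(=O)c2ccccn2)Cc2cc(C#N)ccc21` gives 0.5 10^-6 cm/s. Compound 2 `Cn1cncc1CN1CC(N(CC2CCN(C(=O)c3ccccc3)CC2)S(=O)(=O)c2ccccn2)Cc2cc(C#N)ccc21`, which carries phenyl in place of tert-butyl on a carbonyl carbon, gives 0.5 10^-6 cm/s. Compound 3 `Cn1cncc1CN1CC(N(CC2CCN(C(=O)C3CC3)CC2)S(=O)(=O)c2ccccn2)Cc2cc(C#N)ccc21`, with cyclopropyl on that carbonyl carbon, gives 0.5 10^-6 cm/s. All three sit level: the steps were no change at the digits printed from compound 1 to compound 2 (within the scatter), no change at the digits printed from compound 1 to compound 3 (within the scatter) and no change at the digits printed from compound 2 to compound 3 (within the scatter). Compound 3 therefore stands at the same low level as compound 1 and compound 2 on this read-out.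

Compound 4 `Cn1cncc1CN1CC(N(CC2CCN(C(=O)c3cccs3)CC2)S(=O)(=O)c2ccccn2)Cc2cc(C#N)ccc21` is not yet measured. Its difference from compound 3 is thiophen-2-yl in place of cyclopropyl on a carbonyl carbon. The measured step that bears most on this change is no change at the digits printed from compound 2 to compound 3 (within the scatter), where an aromatic ring on the carbonyl carbon was exchanged for cyclopropyl without movement beyond the scatter; the other two exchanges at the same carbonyl carbon also gave none. The expected step is therefore no change at the digits printed from compound 3 to compound 4 (within the scatter), that is, nothing beyond the scatter. Compound 4 is estimated at 0.5 10^-6 cm/s, with a range from 0.25 10^-6 cm/s to 1 10^-6 cm/s.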

Compound 4, apparent permeability: 0.5 10^-6 cm/s
Estimate against measurement, compound 4: no gap at the digits printed; measured number inside the range.
By their numbers in this assay, from the lowest: compounds 1, 2, 3 and 4 (each within the scatter of the next).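

At this position, on a carbonyl carbon whose other neighbour is an amide-type nitrogen in a ring, a ring holding a hetero atom now joins the all-carbon groups, and this assay gives no change at the digits printed from compound 3 to compound 4 (within the scatter) and no change at the digits printed from compound 2 to compound 4 (within the scatter) and also no change at the digits printed from compound 1 to compound 4 (within the scatter) in the same series. Thiophen-2-yl brings 5 heavy atoms, including sulfur, and 1 hydrogen-bond acceptor in place of the 3 carbon atoms and 0 acceptors of cyclopropyl, yet this larger change in what is counted leaves the reading where it was. Nothing shown here gives a reason for this flat result.

Going by these compounds alone, still open is whether a chain ending in an amine or a carboxylic acid on that carbonyl carbon would give a reading different from the one for compound 4 at 0.5 10^-6 cm/s in this assay. Going by these compounds, all four compounds also share the rest of their structure, so the effect of changes elsewhere on the core of compound 1 remains unknown.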